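The source may hold more compounds than are shown below. What is called first, only, known or untested is meant among the compounds shown, and "the series" means these compounds.

Compound 1 `C#CCNC1CCc2c(NCc3ccccc3)cccc21` is the parent of the set. In an assay on cells for inhibition of Amine oxidase [flavin-containing] B (Homo sapiens), read by fluorescence and Amplex Red, with stated times of 30 min and 15 min (a higher number here means a weaker inhibitor, a lower number a stronger inhibitor), compound 1 gives only a limit, > 20000 nM, and that is the limit of > 20000 nM in this assay, at which 1 of the 3 values shown sits. Compound 2 `C#CCNC1CCc2c(NCc3cccc(F)c3)cccc21` and compound 3 `C#CCNC1CCc2c(NCc3ccc(F)cc3)cccc21` each add a single fluorine to the parent. In this assay compound 2 gives 1860 nM, and compound 3 gives 980 nM. Compound 3 thus holds the lowest of the two numbers, with compound 2 nearest; the step of a 1.9-fold lower number from compound 2 to compound 3 (0.28 log units; within the scatter) lies within the scatter, so no order between the two can be claimed. Against the parent both steps were large: an at least 10-fold lower number from compound 1 to compound 2 (1.03 log units; beyond the scatter) and an at least 20-fold lower number from compound 1 to compound 3 (1.30 log units; beyond the scatter).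

Compound 4 `C#CCNC1CCc2c(NCc3cccc(Br)c3)cccc21` has not been measured. It differs from compound 3 by 3-bromophenyl in place of 4-fluorophenyl on a saturated chain carbon bound to a nitrogen on an aromatic ring. Two things change at once: where the halogen sits on the ring, and which halogen it is. On the first, the step of a 1.9-fold lower number from compound 2 to compound 3 (0.28 log units; within the scatter) bears directly and was within the scatter. Within the data shown here, on fluorine against bromine, none of the measured steps bears. The expected step of a 1.5-fold higher number from compound 3 to compound 4 (0.18 log units; within the scatter) is therefore small, but with a wide range. Compound 4 is estimated at 1500 nM, between 400 nM and 6000 nM.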

Compound 4, half-maximal inhibitory concentration: 110 nM
Compound 4: middle estimate off by 14-fold (1.13 log units), on the high side; measured number outside the range, below it.
By their numbers in this assay, from the lowest: compound 4; then compounds 3 and 2 (each within the scatter of the next). At a limit, above all of these: compound 1.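

Among these compounds, with the ring position held, the halogen itself now counts: bromo in place of fluoro gives a 17-fold lower number from compound 2 to compound 4 (1.23 log units; beyond the scatter) in this assay and the earlier compounds, which carried only fluoro, could not show this. The double change gives an 8.9-fold lower number from compound 3 to compound 4 (0.95 log units; beyond the scatter) whereas moving fluoro alone had given a 1.9-fold lower number from compound 2 to compound 3 (0.28 log units; within the scatter) and so the choice of halogen matters more here than the one shift of position measured with fluoro. Against the parent, bromo gives an at least 180-fold lower number from compound 1 to compound 4 (2.25 log units; beyond the scatter) and this size is only a bound, since compound 1 stands at a limit: the limit of > 20000 nM in this assay, at which 1 of the 4 values shown sits.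

As far as these compounds go, whether the gain belongs to bromo alone stays open, as chloro, iodo or a methoxy group in the same place would be needed to tell. From the compounds shown here alone, it is also open whether 4-bromophenyl would match 3-bromophenyl, since position has been compared only with fluoro.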